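A few compounds are considered here, and "the series" means these few. Any claim that something is new, unique, unknown or untested is made for them only; others in the source may bear on it.

Measured so far, in a functional assay on CCRF-CEM cells (Homo sapiens) for inhibition; on this read-out lower numbers stand for stronger inhibition and higher numbers for weaker inhibition:

compound 1 `O=C1/C(=C/c2ccc(Cl)cc2)Cc2ccccc21` gives 284000 nM
compound 2 `O=C1/C(=C/c2ccc(Br)cc2)Cc2ccccc21` gives 284000 nM
compound 3 `O=C1CCCCC/C1=C\c1cccc(Cl)c1` gives 40500 nM

Compound 3 stands lowest of the three in this assay; its steps to compound 1 and to compound 2 are both beyond the scatter. The cores of compound 1 and compound 3 differ in more than one place; the difference between the two cores is not broken down here.

From compound 1 to compound 2 the change is bromo in place of chloro on an aromatic carbon; it made no change at the digits printed from compound 1 to compound 2 (within the scatter).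

Compound 4 `O=C1CCCCC/C1=C\c1cccc(Br)c1` is not yet measured. It differs from compound 3 by bromo in place of chloro on an aromatic carbon, the same kind of change as from compound 1 to compound 2, though the place differs: here meta to a group of 9 heavy atoms, there para to a large group. Resting on the step from compound 1 to compound 2, no change at the digits printed from compound 1 to compound 2 (within the scatter), the step from compound 3 to compound 4 is expected to be no change at the digits printed from compound 3 to compound 4 (within the scatter). Compound 4 is therefore estimated at 40500 nM, expected between 20000 nM and 85000 nM.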

Compound 4, half-maximal inhibitory concentration: 137000 nM
The estimate for compound 4 lay 3.4-fold (0.53 log units) below the measured number; the whole stated range lies below it.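

In this assay, bromo in place of chloro gave a 3.4-fold higher number from compound 3 to compound 4 (0.53 log units; beyond the scatter), so the step did not carry over unchanged from one core to the other: the same change on two cores in this assay, no change at the digits printed (within the scatter) from compound 1 to compound 2 and a 3.4-fold higher number (0.53 log units; beyond the scatter) from compound 3 to compound 4, 3.4-fold (0.53 log units) apart, beyond the scatter of two such steps

The two pairs differ in the core and also in the place of the halogen on the aromatic ring, and the data do not separate these two differences. Two pairs also give no rule for carrying this change to any further core in the series.

Going by these compounds, it remains open how chloro and bromo compare on the core of compound 3 with the halogen placed as in compound 1. Also open, on these data alone, is how fluoro, methoxy or an amine on the same aromatic ring would stand.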